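Swapping a bromobenzyl for a cyclopropylmethyl on a weak inhibitor

The source may hold more compounds than are shown below. What is called first, only, known or untested is meant among the compounds shown, and "the series" means these compounds.

Compound 1 `Cc1cc(Nc2cc(-c3ccccc3)[nH]n2)n2nc(SCc3ccc(Br)cc3)nc2n1` is tested in an ADME assay on GES1 cells (Homo sapiens) for inhibition, read by MTT assay, with a stated time of 72 h (on this read-out higher numbers stand for weaker inhibition and lower numbers for stronger inhibition), and gives 39300 nM, the lowest of the two numbers recorded, though compound 2 `Cc1cc(Nc2ccn(Cc3ccc(F)cc3)n2)n2nc(SCc3ccc(Br)cc3)nc2n1` gives 40500 nM in this assay, a gap within the scatter. Compound 3 `Cc1cc(Nc2cc(-c3ccccc3)[nH]n2)n2nc(SCC3CC3)nc2n1` is not yet measured in this assay; it differs from compound 1 by cyclopropyl in place of 4-bromophenyl on a saturated chain carbon bound to a sulfur. Within the data shown here, no step between measured compounds involves this change, so compound 3 is expected to stay close to compound 1, with at most a small step of a 1.1-fold higher number from compound 1 to compound 3 (0.06 log units; within the scatter) toward weaker inhibition. For compound 3 the estimate is 45000 nM, with a range from 20000 nM to 100000 nM.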

Compound 3, half-maximal inhibitory concentration: > 50000 nM
Compound 3: only a limit was reported; the forecaster's own chance of this, stated with the estimate: 25%; middle value at least 1.1-fold (0.04 log units) away from the limit.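

Compound 3 gives only a limit in this assay, so its result is a floor and not a number: the limit of > 50000 nM in this assay, at which 1 of the 3 values shown sits.

On a saturated chain carbon bound to a sulfur, cyclopropyl in place of 4-bromophenyl gives an at least 1.2-fold higher number from compound 1 to compound 3 (0.10 log units; that floor lies within the scatter), so this change brings no visible strengthening of inhibition. Whether the two compounds truly differ cannot be read from this floor.

On these data alone, it remains open how a longer chain, an amine or a carboxylic acid on that chain carbon would read, and whether the same change on compound 2 would behave alike.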